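The source may hold more compounds than are shown below. What is called first, only, known or untested is meant among the compounds shown, and "the series" means these compounds.

Measured so far: compound 1 `CC1=C(C(=O)CC(C)C)C(c2ccoc2)NC(=O)N1` with 1010 nM in an assay on membranes from HEK293 cells for displacement of a labelled ligand from adenosine receptor A2b (Homo sapiens), read by scintillation counting, with a stated time of 30 min; a higher number here means a weaker inhibitor, a lower number a stronger inhibitor; compound 2 `CC1=C(C(=O)SC(C)C)C(c2ccoc2)NC(=O)N1` with 637 nM in this assay.

For the measured compounds named here, compound 2 holds the lower of the two numbers in this assay, but the only measured step, a 1.6-fold lower number from compound 1 to compound 2 (0.20 log units; within the scatter), lies within the scatter, so the two compounds are not separated.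

Compound 3 `CC1=C(c2ncc(C)o2)C(c2ccoc2)NC(=O)N1` is unmeasured. It differs from compound 2 in one place: 5-methyl-1,3-oxazol-2-yl in place of (isopropylsulfanyl)carbonyl on a double-bonded ring carbon. Going by the values given here, the one measured step exchanged the chain attached to the carbonyl carbon, and the carbonyl itself stayed in place; here the whole (isopropylsulfanyl)carbonyl group is removed and an aromatic ring enters at the double-bonded ring carbon of the shared core. Among the compounds with values here, no measured step covers that kind of exchange, so the step from compound 1 to compound 2 bears on it only loosely, and no direction beyond the scatter can be expected.

Compound 3 is therefore estimated at 700 nM, range 150 nM to 3500 nM, which is a step of a 1.1-fold higher number from compound 2 to compound 3 (0.04 log units; within the scatter) from compound 2 expected to lie within the scatter.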

Compound 3, inhibition constant: 801 nM
Compound 3: the middle estimate sits 1.1-fold (0.06 log units) below what was measured; measured number inside the range.
By their numbers in this assay, from the lowest: compounds 2, 3 and 1 (each within the scatter of the next).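

In this assay the double-bonded ring carbon tolerates replacement of the whole carbonyl-bearing group, not only a change of the chain on the carbonyl: a 1.3-fold higher number from compound 2 to compound 3 (0.10 log units; within the scatter) and a 1.3-fold lower number from compound 1 to compound 3 (0.10 log units; within the scatter) both stay within the scatter. Among these three compounds a carbonyl at this position is therefore not needed for a number in this range, and 5-methyl-1,3-oxazol-2-yl, a five-membered aromatic ring, is not separated from either the (isopropylsulfanyl)carbonyl or the isobutylcarbonyl group. Nothing available bears on this result.

From the compounds shown here alone, whether a carboxylic acid, an amine or a longer chain at this position would move the number beyond the scatter remains open. So does whether other aromatic rings, such as phenyl or pyridyl, would match 5-methyl-1,3-oxazol-2-yl here.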